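Compound 2 to compound 3: expected cytotoxicity

The source may hold more compounds than are shown below. What is called first, only, known or untested is meant among the compounds shown, and "the series" means these compounds.

Compound 1 `Cc1nc(C(NC(=O)C(=O)Nc2ccc(Cl)cc2)C2CCCCN2)sc1CO`: > 108000 nM (limit)
Compound 2 `Cc1nc(C(NC(=O)C(=O)Nc2ccc(F)cc2F)C2CCCCN2)sc1CCO`: > 105000 nM (limit)

In an ADME assay on MT2 cells (Homo sapiens) for cytotoxicity, read by XTT assay, with a stated time of 4 days (on this read-out higher numbers stand for lower toxicity in this test and lower numbers for higher toxicity in this test), compound 2 gives > 105000 nM, which is a limit of the assay and not a number. Compound 1 gives > 108000 nM, which is also a limit. Within the data shown here, no step between measured compounds is available. Compound 3 `Cc1nc(C(NC(=O)C(=O)Nc2ccc(Cl)cc2)C2CCCCN2)sc1CCO` carries 4-chlorophenyl in place of 2,4-difluorophenyl on an amide-type nitrogen. The expected a number no higher from compound 2 to compound 3 (the limit leaves the size open) stays within the usual scatter, with no direction expected. For compound 3 the estimated value is 105000 nM, with an expected range of 50000 nM to 200000 nM.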

Compound 3, half-maximal cytotoxic concentration: > 62000 nM
Compound 3 was reported as a limit; the forecaster's own chance of this, stated with the estimate: 80%; the middle value is on the limit's open side.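

Neither the step from compound 2 to compound 3 nor the step from compound 1 to compound 3 can be read in this assay: all three results are limits. The compounds shown leave open whether either change shifts the half-maximal cytotoxic concentration at all.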